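A few compounds are considered here, and "the series" means these few. Any claim that something is new, unique, unknown or untested is made for them only; others in the source may bear on it.

Measured compounds:
compound 1, `CCCC(=O)Nc1ccc(S(=O)(=O)Oc2ccccc2C(C)C)cc1`: 950 nM
compound 2, `CC(C)c1ccccc1OS(=O)(=O)c1ccc(NC(=O)CCl)cc1`: 1000 nM
compound 3, `CCCNC(=O)Nc1ccc(S(=O)(=O)Oc2ccccc2C(C)C)cc1`: 680 nM

All three share one core and differ only in the group attached to the carbonyl carbon of the amide. In a functional assay on HT-1080 cells (Homo sapiens) for antiproliferative activity, read by sulforhodamine B assay, with a stated time of 48 h (a lower number here means a stronger inhibitor, a higher number a weaker inhibitor), compound 1 gives 950 nM, compound 2 gives 1000 nM and compound 3 gives 680 nM. The steps between them are small: a 1.1-fold higher number from compound 1 to compound 2 (0.02 log units; within the scatter), a 1.4-fold lower number from compound 1 to compound 3 (0.15 log units; within the scatter) and a 1.5-fold lower number from compound 2 to compound 3 (0.17 log units; within the scatter). Compound 3 thus sits at the low end of the three numbers, but not by a margin that rises above the scatter.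

Compound 4, `CC(C)c1ccccc1OS(=O)(=O)c1ccc(NC(=O)NC2CCCC2)cc1`, is the next step from compound 3. Within the data shown here, the change is cyclopentyl in place of propyl on an amide-type nitrogen, the amide-type nitrogen being the one whose other neighbour is the carbonyl carbon. Among the measured compounds shown here, none of the measured steps alters this part of the molecule; they all touch the group on the other side of the carbonyl. For the measured compounds named here, those steps, all within the scatter, show that the series so far reacts mildly to changes at the amide end, and exchanging a propyl for a cyclopentyl on the nitrogen is a comparable change in size. The expected step is a 1.1-fold lower number from compound 3 to compound 4 (0.05 log units; within the scatter), estimated to stay within the scatter. Compound 4 is therefore expected to give 600 nM, with an estimated range from 250 nM to 1500 nM.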

Compound 4, half-maximal inhibitory concentration: 3900 nM
Beside the measured number, compound 4's estimate is 6.5-fold (0.81 log units) below it, and the stated range ends below it.
By their numbers in this assay, from the lowest: compounds 3, 1 and 2 (each within the scatter of the next); then compound 4.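

In this assay, among these compounds, the group on the amide-type nitrogen turns out to matter: a 5.7-fold higher number from compound 3 to compound 4 (0.76 log units; beyond the scatter) when cyclopentyl replaces propyl there, and this is the first step in the set that lies beyond the scatter. Against the compounds with other groups on the carbonyl carbon the picture is the same, with a 4.1-fold higher number from compound 1 to compound 4 (0.61 log units; beyond the scatter) for cyclopentylamino in place of propyl and a 3.9-fold higher number from compound 2 to compound 4 (0.59 log units; beyond the scatter) for cyclopentylamino in place of chloromethyl, so the series that looked tolerant of change at this carbonyl carbon does not tolerate every group there. The data offer no measurement that accounts for this loss.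

On these data alone, what stays open is whether the ring itself or simply the larger number of carbons lies behind the step, a question that an open pentyl or butyl chain on the same nitrogen could help to settle. The shown compounds also leave open how a smaller cyclopropyl ring, a larger cyclohexyl ring, or a cyclopentyl ring carrying a hydroxyl group or an amine would behave at this position.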